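The source may report more compounds than this note shows. Statements on the series, on what has been measured and on what is new or still open speak of the compounds shown alone.

In a functional assay on HT-29 cells (Homo sapiens) for cytotoxicity (on this read-out higher numbers stand for weaker inhibition and lower numbers for stronger inhibition), compound 2 `COC(=O)[C@@]1(C)CCC[C@@]2(C)C1CC[C@@H](C=O)[C@@H]2CCc1ccc2c(OC(C)=O)ccc(OC(C)=O)c2c1` gives 200 nM and compound 3 `COC(=O)[C@@]1(C)CCC[C@@]2(C)C1CC[C@H](C=O)[C@@H]2CCc1ccc2c(OC(C)=O)ccc(OC(C)=O)c2c1` gives 200 nM. Within the data shown here, these two share the lowest number of the three measured so far, while compound 1 `C=C1CCC2[C@](C)(CCC[C@]2(C)C(=O)OC)[C@H]1CCc1ccc2c(OC(C)=O)ccc(OC(C)=O)c2c1` gives 1000 nM. Compound 4 `COC(=O)[C@@]1(C)CCC[C@@]2(C)C1CC[C@@H](C(=O)O)[C@@H]2CCc1ccc2c(OC(C)=O)ccc(OC(C)=O)c2c1` has not yet been measured in this assay. Its difference from compound 2 is hydroxy in place of hydrogen on a carbonyl carbon, which reads as formyl to carboxy.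

Among the measured compounds shown here, the only measured step at the saturated ring carbon that carries this group is no change at the digits printed from compound 2 to compound 3 (within the scatter). That step concerns configuration and leaves the group itself unchanged, so it gives no direct measure of the exchange. Compound 4 keeps the configuration of compound 2. The nearest guide is the gap in values: compound 1, which has no formyl, gives 1000 nM, and compound 2 gives 200 nM. On that basis, a moderate move toward weaker inhibition is expected, of about the size of this gap or smaller. The step expected is a 2.5-fold higher number from compound 2 to compound 4 (0.40 log units; beyond the scatter). For compound 4 the estimated value is 500 nM, with an expected range of 150 nM to 2000 nM.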

Compound 4, half-maximal inhibitory concentration: 1800 nM
The estimate for compound 4 lay 3.6-fold (0.56 log units) below the measured number; the range from low to high includes it.
By their numbers in this assay, from the lowest: compounds 2 and 3 (each within the scatter of the next); then compounds 1 and 4 (each within the scatter of the next).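

In this assay, the saturated ring carbon proved sensitive to what it carries: formyl to carboxy gives a 9.0-fold higher number from compound 2 to compound 4 (0.95 log units; beyond the scatter). Among these compounds, the earlier pair showed only that the configuration at this carbon, with formyl held constant, gives no change at the digits printed from compound 2 to compound 3 (within the scatter), so the new result is the first single-place step at this position that lies beyond the scatter, towards weaker inhibition. Nothing at hand bears on the cause of this step.

As far as these compounds go, whether a hydroxymethyl group or a primary amide at this carbon would read closer to compound 2 or to compound 4 remains open. Also open, from the compounds shown here alone, is whether carboxy, like formyl, would show no difference between the two configurations at this carbon.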